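Two Methoxy Groups in Place of Two Methyls

A few compounds are considered here, and "the series" means these few. Any claim that something is new, unique, unknown or untested is made for them only; others in the source may bear on it.

Three thiourea compounds built on one shared core have been tested in a functional assay on the whole organism (strain L.) for inhibition, with Echinochloa crus-galli as the target, with a stated time of 72 h, tested at 100 mg/L; a lower number here means less inhibition of growth, a higher number more inhibition of growth at the concentration tested. Compound 1 `COc1cc(SC)nc(NC(=S)NC(=O)c2c(-c3ccc(Cl)cc3Cl)noc2C)n1` gives 40.9% in this assay. Compound 2 `CSc1cc(C)nc(NC(=S)NC(=O)c2c(-c3ccc(Cl)cc3Cl)noc2C)n1` gives 47.1%. Compound 3 `Cc1cc(C)nc(NC(=S)NC(=O)c2c(-c3ccc(Cl)cc3Cl)noc2C)n1` gives 64.7%, the highest of the three numbers, and its lead over each of the other two lies beyond the scatter. The three differ only in the two groups carried by the ring attached to the amide-type nitrogen.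

Compound 4 `COc1cc(OC)nc(NC(=S)NC(=O)c2c(-c3ccc(Cl)cc3Cl)noc2C)n1` has not been measured yet. It differs from compound 3 by 4,6-dimethoxypyrimidin-2-yl in place of 4,6-dimethylpyrimidin-2-yl on an amide-type nitrogen. Among the measured compounds shown here, two measured steps bear on this change. Swapping a methylsulfanyl for a methyl gave a number 17.6 percentage points higher from compound 2 to compound 3 (beyond the scatter), so moving away from methyl cost a modest amount. Swapping a methoxy for a methyl gave a number 6.2 percentage points higher from compound 1 to compound 2 (within the scatter), which makes methoxy and methylsulfanyl look alike here. Replacing both methyls at once gave a number 23.8 percentage points higher from compound 1 to compound 3 (beyond the scatter). Compound 4 swaps both methyls for methoxy, so a drop of similar size is expected. For compound 4 a modest fall is therefore estimated, namely a number 26.7 percentage points lower from compound 3 to compound 4 (beyond the scatter). Compound 4 is expected to give 38% in this assay, with a likely range from 22% to 55%.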

Compound 4, percent growth inhibition at one concentration: 60.9%
Estimate against measurement, compound 4: 22.9 percentage points below, outside the stated range (above it).
By their numbers in this assay, from the lowest: compounds 1 and 2 (each within the scatter of the next); then compounds 4 and 3 (each within the scatter of the next).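

In this assay, putting 4,6-dimethoxypyrimidin-2-yl in place of 4,6-dimethylpyrimidin-2-yl on the amide-type nitrogen gives a number 3.8 percentage points lower from compound 3 to compound 4 (within the scatter), so two methoxy groups serve as well as two methyls and moving away from methyl does not by itself lower the number. Among the compounds shown here, the lower numbers instead go with methylsulfanyl, which is carried by both lower-lying compounds and by neither of the two higher ones: the clearest case is the single swap of methoxy in place of methylsulfanyl, with a number 20 percentage points higher from compound 1 to compound 4 (beyond the scatter), and the ring change that removes methylsulfanyl and methyl together gives a number 13.8 percentage points higher from compound 2 to compound 4 (beyond the scatter). Nothing measured here explains why methylsulfanyl goes with less inhibition of growth, or why methoxy and methyl sit so close together.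

Among these four compounds the methylsulfanyl pattern has no exception, but it rests on one sulfur-linked group, so it remains open whether a longer chain such as ethylsulfanyl or ethoxy, an amine such as dimethylamino, or a chlorine atom on the ring would follow it. Each number also comes from a single concentration, which leaves open whether compound 3 and compound 4 would stay this close at lower concentrations.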